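Replacing dimethylamino in compound 3 with a longer chain

The source may report more compounds than this note shows. Statements on the series, on what has been measured and on what is new or still open speak of the compounds shown alone.

In a functional assay on MCF7 cells (Homo sapiens) for cytotoxicity, read by neutral red uptake, with a stated time of 3 days (a higher number here means a weaker inhibitor, a lower number a stronger inhibitor), compound 1 `CCCCCCc1c(F)c(N)c2c(=O)cc(-c3ccc(N)c(F)c3)oc2c1F` reads > 10000 nM, which is a limit of the assay and not a number. Compound 2 `[N-]=[N+]=Nc1c(F)c(N)c2c(=O)cc(-c3ccc(N)c(F)c3)oc2c1F` gives 460 nM. Compound 3 `CN(C)c1c(F)c(N)c2c(=O)cc(-c3ccc(N)c(F)c3)oc2c1F` gives 39 nM, the lowest number of the three, and a 12-fold lower number from compound 2 to compound 3 (1.07 log units; beyond the scatter) separates it from its nearest neighbour.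

The unmeasured compound 4 `CN(C)CC(=O)OCc1c(F)c(N)c2c(=O)cc(-c3ccc(N)c(F)c3)oc2c1F` keeps the shared core, but ((((dimethylamino)methyl)carbonyl)oxy)methyl stands in place of dimethylamino on the same aromatic carbon: ((((dimethylamino)methyl)carbonyl)oxy)methyl in place of dimethylamino on an aromatic carbon.

Among the compounds with values here, all the measured steps fall at this one place, and all are large: an at least 21-fold lower number from compound 1 to compound 2 (1.33 log units; beyond the scatter), a 12-fold lower number from compound 2 to compound 3 (1.07 log units; beyond the scatter) and an at least 250-fold lower number from compound 1 to compound 3 (2.40 log units; beyond the scatter). A sizeable change is therefore expected here too. The only other long chain, the hexyl of compound 1, sits on the high side of an at least 250-fold lower number from compound 1 to compound 3 (2.40 log units; beyond the scatter), so the expected direction is upward, though probably by less, since the new chain still ends in dimethylamino. The expected change is a 5.1-fold higher number from compound 3 to compound 4 (0.71 log units; beyond the scatter). Compound 4 is estimated at 200 nM, with an expected range of 25 nM to 2500 nM.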

Compound 4, half-maximal inhibitory concentration: 26 nM
For compound 4 the middle estimate is 7.7-fold (0.89 log units) above the measured one; the range from low to high includes it.
By their numbers in this assay, from the lowest: compounds 4 and 3 (each within the scatter of the next); then compound 2. At a limit, above all of these: compound 1.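

In this assay, this aromatic carbon accepts a much larger group than dimethylamino, as the ((((dimethylamino)methyl)carbonyl)oxy)methyl chain of compound 4 gives a 1.5-fold lower number from compound 3 to compound 4 (0.18 log units; within the scatter), so a long chain here does not by itself mean a high number. Compound 4 also stands clear of the azido compound, with an 18-fold lower number from compound 2 to compound 4 (1.25 log units; beyond the scatter), and the two long chains now part widely, with an at least 380-fold lower number from compound 1 to compound 4 (2.58 log units; beyond the scatter). That step rests on a reading for compound 1 that is a limit of the assay and not a number: the limit of > 10000 nM in this assay, at which 1 of the 4 values shown sits.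

Which part of the new chain matters stays open: the terminal dimethylamino, or the carbonyl and oxygen that link it. A chain ending in a carboxylic acid, or an amide in place of the ester link, would separate these parts.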